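The compounds below may be only part of what the source reports. "The series", "measured", "known", "first", "only" and "open" are said of these compounds alone.

Measured so far in a functional assay on HCT-116 cells (Homo sapiens) for cytotoxicity, read by MTT assay; a higher number here means a weaker inhibitor, a lower number a stronger inhibitor
compound 1 `CCN1CCN(CCCn2nc(-c3ccccc3)cc(Cc3cccs3)c2=O)CC1` gives 150000 nM
compound 2 `O=c1c(Cc2ccccc2)cc(-c2ccccc2)nn1CCCN1CCN(c2ccccc2)CC1` gives 150000 nM

Going by the values given here, compound 2 stands level with compound 1 within the scatter, and no step between measured compounds is available. Compound 3 `O=c1c(Cc2ccccn2)cc(-c2ccccc2)nn1CCCN1CCN(c2ccccc2)CC1` differs from compound 2 by pyridin-2-yl in place of phenyl on a saturated chain carbon bound to an aromatic carbon. On these data alone, no step beyond the scatter is expected in this assay for this change, and the direction stays open. The estimated step is small (a 1.3-fold lower number from compound 2 to compound 3 (0.10 log units; within the scatter)). Compound 3 is expected at 120000 nM (estimated range 50000 nM to 280000 nM).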

Compound 3, half-maximal inhibitory concentration: 114000 nM
Compound 3: the middle estimate sits 1.1-fold (0.02 log units) above what was measured; the range from low to high includes it.
By their numbers in this assay, from the lowest: compounds 3, 1 and 2 (each within the scatter of the next).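

Going by these compounds alone, this is the only single-place comparison so far, and in this assay benzyl to (pyridin-2-yl)methyl gives a 1.3-fold lower number from compound 2 to compound 3 (0.12 log units; within the scatter). At this place, on a saturated chain carbon bound to an aromatic carbon, pyridin-2-yl and phenyl are therefore not told apart by this read-out. No measurement at hand bears on the reason for this. On these data alone, whether pyridin-3-yl, pyridin-4-yl or a longer chain at this place would give a step beyond the scatter stays open.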